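Replacing Bromo with Ethylamino on a Saturated Chain Carbon

The source may hold more compounds than are shown below. What is called first, only, known or untested is meant among the compounds shown, and "the series" means these compounds.

In a functional assay on HeLa cells (Homo sapiens) for antiproliferative activity, read by MTT assay, with a stated time of 48 h (a lower number here means a stronger inhibitor, a higher number a weaker inhibitor), compound 2 (`COc1ccc(C(=O)c2ccc3c(c2)C=CC(C)(C)O3)c(NC(=O)CBr)c1`) gives 3050 nM. Compound 1 (`COc1ccc(C(=O)c2ccc(OC)c3c2OC(C)(C)C=C3)c(NC(=O)CBr)c1`), at 2140 nM, stands within the usual scatter of that number. Compound 3 (`COc1ccc(C(=O)c2ccc(OC)c3c2C=CC(C)(C)O3)c(NC(=O)CO)c1`) gives 310 nM, a number lower by more than the scatter, so compound 2 sits at the high end of this small set, level with compound 1. Compound 4 (`CCNCC(=O)Nc1cc(OC)ccc1C(=O)c1ccc2c(c1)C=CC(C)(C)O2`) keeps the core of compound 2 and changes one place: ethylamino in place of bromo on a saturated chain carbon bound to a carbonyl carbon. Going by the values given here, no two measured compounds differ in one place only, so no measured step guides this change. Among the compounds with values here, the only hint is compound 3 at 310 nM, which also carries no bromo, though it differs from compound 2 elsewhere too. A modest fall in this assay is therefore expected, one that may not clear the scatter. The estimated change is a 1.5-fold lower number from compound 2 to compound 4 (0.18 log units; within the scatter). For compound 4 the expected value is 2000 nM, with an estimated range of 450 nM to 9000 nM.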

Compound 4, half-maximal inhibitory concentration: 3110 nM
Compound 4: middle estimate off by 1.6-fold (0.19 log units), on the low side; measured number inside the range.
By their numbers in this assay, from the lowest: compound 3; then compounds 1, 2 and 4 (each within the scatter of the next).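

In this assay, this position now has its first single-place step, which reads a 1.0-fold higher number from compound 2 to compound 4 (0.01 log units; within the scatter), with ethylamino in place of bromo on a saturated chain carbon bound to a carbonyl carbon. On the core of compound 2, then, losing the bromo does not by itself shift the number beyond the scatter, and neither do the larger group and its added hydrogen-bond donor and acceptor. Nothing available explains why the two compounds stay level.

Still open, as far as these compounds go, is whether another group at this place, such as dimethylamino, a carboxylic acid or a longer alkylamino chain, would move the number beyond the scatter. Also open, from the compounds shown here alone, is whether hydroxy, which compound 3 carries on a differently substituted core, would do so on the core of compound 2.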